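From 2-fluorophenyl to 4-ethylphenyl on the amine nitrogen

A few compounds are considered here, and "the series" means these few. Any claim that something is new, unique, unknown or untested is made for them only; others in the source may bear on it.

Compound 1 `O=C1C=C(N2CCC2)C(=O)c2c1nc1n2[C@H]2OC[C@@H](O)[C@H]2OC1`: > 16000 nM (a limit)
Compound 2 `O=C1C=C(Nc2ccccc2F)C(=O)c2c1nc1n2[C@H]2OC[C@@H](O)[C@H]2OC1`: 2080 nM

Both readings come from a functional assay on MGC-803 cells (Homo sapiens) for inhibition, read by sulforhodamine B assay; a lower number here means a stronger inhibitor, a higher number a weaker inhibitor. For compound 1, > 16000 nM is a limit and not a number. Among the compounds with values here, compound 2, at 2080 nM, therefore holds the only actual number so far.

Within the data shown here, the one measured step is an at least 7.6-fold lower number from compound 1 to compound 2 (0.88 log units; beyond the scatter). It exchanges the whole group on the double-bonded ring carbon, with azetidin-1-yl leaving and (2-fluorophenyl)amino entering.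

Compound 3 `CCc1ccc(NC2=CC(=O)c3nc4n(c3C2=O)[C@H]2OC[C@@H](O)[C@H]2OC4)cc1` keeps the arylamino arrangement and changes only the aryl group: 4-ethylphenyl in place of 2-fluorophenyl on an amine nitrogen. This is 4-ethylphenyl in place of 2-fluorophenyl on an amine nitrogen. Among the measured compounds shown here, the step to compound 2 bears on this only loosely, since no measured pair compares two aryl groups. It gives no direction for the present change, and a step of its size is not expected here. No step beyond the scatter is therefore expected in this assay, and the estimate stays anchored on compound 2 at 2080 nM.

The expected change is a 1.0-fold lower number from compound 2 to compound 3 (0.02 log units; within the scatter).

Compound 3 is estimated at 2000 nM, with an expected range of 600 nM to 7000 nM.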

Compound 3, half-maximal inhibitory concentration: 1290 nM
The estimate for compound 3 lay 1.6-fold (0.19 log units) above the measured number, within the range that was stated.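

In this assay, the exchange on the amine nitrogen gives a 1.6-fold lower number from compound 2 to compound 3 (0.21 log units; within the scatter), so 2-fluorophenyl and 4-ethylphenyl are not told apart by this read-out, even though the two groups differ in what they carry and where the name places it. The replacement of azetidin-1-yl now has a second example, an at least 12-fold lower number from compound 1 to compound 3 (1.09 log units; beyond the scatter), and with two different aryl groups on the amine nitrogen, both arylamino compounds fall on the same side of compound 1. Compound 1 holds a limit and not a number, so the true size of both steps from it stays undefined on one side: the limit of > 16000 nM in this assay, at which 1 of the 3 values shown sits.

As far as these compounds go, it remains open whether the aromatic ring itself is what separates compound 2 and compound 3 from compound 1, which an open-chain amine such as diethylamino or a benzylamino group on the same ring carbon would address. Also open, from the compounds shown here alone, is how far the aryl group tolerates change, for example a carboxylic acid, a methoxy group or a longer alkyl chain in place of the ethyl group.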